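This account rests on a few compounds, and the source may have more. Where it says the series, first, only, none or still open, it means among the compounds named here.

Measured in a functional assay on A549 cells (Homo sapiens) for cytotoxicity, read by MTT assay, with a stated time of 48 h; on this read-out higher numbers stand for weaker inhibition and lower numbers for stronger inhibition:
Compound 1 `COc1cc(-n2c(-c3ccccc3)cn(C(C)=O)c2=O)cc(OC)c1OC`: > 50000 nM, a limit of the assay
Compound 2 `COc1ccc(-c2cn(C(C)=O)c(=O)n2-c2cc(OC)c(OC)c(OC)c2)cc1`: 17800 nM
Compound 3 `COc1cc(-n2c(-c3ccc(F)cc3F)cn(C(C)=O)c2=O)cc(OC)c1OC`: 24100 nM

Compound 3 gives 24100 nM, and the gap to its nearest measured neighbour is a 1.4-fold higher number from compound 2 to compound 3 (0.13 log units; within the scatter). The comparison on its other side runs against a limit: an at least 2.0-fold lower number from compound 1 to compound 3 (0.31 log units; beyond the scatter).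

Compound 4 `COc1ccc(-c2cn(C(C)=O)c(=O)n2-c2cc(OC)c(OC)c(OC)c2)cc1OC` has 3,4-dimethoxyphenyl in place of 2,4-difluorophenyl on an aromatic carbon.

Among the measured compounds shown here, three measured steps bear on this change. Substitution on the phenyl gave an at least 2.8-fold lower number from compound 1 to compound 2 (0.44 log units; beyond the scatter) and an at least 2.0-fold lower number from compound 1 to compound 3 (0.31 log units; beyond the scatter), both modest and both starting from a limit. The exchange between the two substituted rings gave a 1.4-fold higher number from compound 2 to compound 3 (0.13 log units; within the scatter). Compound 2, the closest methoxy-bearing comparison, gives 17800 nM. In this assay, no change beyond the scatter is therefore expected, with any drift towards the lower number of compound 2. The expected step is a 1.5-fold lower number from compound 3 to compound 4 (0.18 log units; within the scatter). For compound 4 the estimated value is 16000 nM, with an expected range of 6000 nM to 45000 nM.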

Compound 4, half-maximal inhibitory concentration: > 50000 nM
Compound 4 ended at the assay's limit; the forecaster's own chance of this, stated with the estimate: 15%; middle value at least 3.1-fold (0.49 log units) from the limit.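

In this assay, adding a methoxy to the aromatic ring of compound 2 does not repeat the earlier gain, and the direction reverses: an at least 2.8-fold higher number from compound 2 to compound 4 (0.44 log units; beyond the scatter). The 3,4-dimethoxyphenyl also compares poorly with the 2,4-difluorophenyl at this aromatic carbon, an at least 2.0-fold higher number from compound 3 to compound 4 (0.31 log units; beyond the scatter), so compound 4 goes against the lower numbers that substitution on the phenyl gave in compound 2 and compound 3. The value of compound 4 is a limit, and compound 1 sits at the same limit, so the step between these two cannot be read: the limit of > 50000 nM in this assay, at which 2 of the 4 values shown sit.

Going by these compounds, how far the number of compound 4 lies beyond that limit stays open. So does whether a hydroxy group, an amine or a longer alkoxy chain on this phenyl would keep the numbers seen for compound 2 and compound 3.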